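The source may hold more compounds than are shown below. What is called first, only, known or untested is meant among the compounds shown, and "the series" means these compounds.

Compound 1 `COc1ccc(-c2cc(/C=C/C(=O)c3ccc(N)cc3)[nH]n2)cc1`: 1890 nM
Compound 2 `COc1cc(-c2cc(/C=C/C(=O)c3ccc(N)cc3)[nH]n2)cc(OC)c1OC`: 1860 nM
Compound 3 `COc1ccc(C(=O)/C=C/c2cc(-c3cc(OC)c(OC)c(OC)c3)n[nH]2)cc1`: 1810 nM

In a functional assay on SN12C cells (Homo sapiens) for inhibition, read by sulforhodamine B assay, with a stated time of 48 h (a higher number here means a weaker inhibitor of growth, a lower number a stronger inhibitor of growth), compound 2 gives 1860 nM, the second highest of the three numbers; its nearest neighbour is compound 1 and its furthest is compound 3, and both gaps lie within the scatter. Compound 4 `COc1ccc(-c2cc(/C=C/C(=O)c3ccc(N)cc3)[nH]n2)cc1OC` differs from compound 2 by hydrogen in place of methoxy on an aromatic carbon. Among the measured compounds shown here, no measured step removes a methoxy group. For the measured compounds named here, the only measured step, a 1.0-fold lower number from compound 2 to compound 3 (0.01 log units; within the scatter), exchanges a different group and stays within the scatter, and compounds 1 and 2, which differ only in methoxy groups, give values within the scatter of each other. The step from compound 2 to compound 4 is therefore expected to be a 1.0-fold higher number from compound 2 to compound 4 (0.00 log units; within the scatter), nothing beyond the scatter. Compound 4 is expected to give 1870 nM, within a range from 900 nM to 3900 nM.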

Compound 4, concentration for 50% growth inhibition: 3530 nM
Estimate against measurement, compound 4: 1.9-fold (0.28 log units) below; the range from low to high includes it.
By their numbers in this assay, from the lowest: compounds 3, 2, 1 and 4 (each within the scatter of the next).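

In this assay the methoxy group on this aromatic carbon can be exchanged for hydrogen with no difference that can be read beyond the scatter (a 1.9-fold higher number from compound 2 to compound 4 (0.28 log units; within the scatter)). The matching exchange, methoxy in place of hydrogen, reads the same way (a 1.9-fold higher number from compound 1 to compound 4 (0.27 log units; within the scatter)). Compound 4 thus gives two direct comparisons of methoxy with hydrogen on this ring, and neither separates them. Nothing measured here offers an explanation for this result. As far as these compounds go, whether a hydroxyl group or a chlorine atom on this carbon would match methoxy and hydrogen remains open.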